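Working notes on a chemokine receptor type 8 antagonist series

A few compounds are considered here, and "the series" means these few. Any claim that something is new, unique, unknown or untested is made for them only; others in the source may bear on it.

compound 1, `COc1ccc2nccc(C3CN(CC4CCCN(Cc5cc6ccccc6[nH]5)C4)C(=O)O3)c2c1`, in an in vitro functional assay on RBL cells for antagonist activity at C-C chemokine receptor type 8 (Homo sapiens), read by FLIPR and calcium flux (on this read-out higher numbers stand for weaker inhibition and lower numbers for stronger inhibition), gives < 50200 nM.
compound 2, `COc1ccc2nccc(C3CN(C4CCN(Cc5c[nH]c6ccccc56)CC4)C(=O)O3)c2c1`, in this assay gives < 50200 nM.

The value given for compound 1 is a limit of the assay, not a number. The value given for compound 2 is likewise a limit of the assay. Going by the values given here, compound 2 therefore stands where every value so far stands: at the limit of < 50200 nM in this assay, at which 2 of the 2 values shown sit. Among the compounds with values here, no step between two measured compounds can be read from this, since neither compound carries a number.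

Compound 3, `COc1ccc2nccc(C3CN(C4CCN(Cc5ccc6ccccc6c5)CC4)C(=O)O3)c2c1`, is the next compound to be measured. It differs from compound 2 in one place: naphthalen-2-yl in place of 1H-indol-3-yl on a saturated chain carbon bound to an amine nitrogen in a ring. Nothing measured in the series separates an indolyl from a naphthyl group, so no direction can be taken from the data. The step from compound 2 to compound 3 is expected to be a step that the limit leaves unreadable from compound 2 to compound 3, that is, none beyond the scatter as far as the limit allows any statement at all.

On this basis compound 3 is estimated at 3000 nM, with a range from 300 nM to 30000 nM.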

Compound 3, half-maximal inhibitory concentration: 1260 nM
Compound 3: the middle estimate sits 2.4-fold (0.38 log units) above what was measured, within the range that was stated.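

Going by these compounds alone, compound 2 carries a limit of the assay and not a number, so no step from it to compound 3 can be read in this assay: the limit of < 50200 nM in this assay, at which 2 of the 3 values shown sit.
The compounds shown leave open whether naphthalen-2-yl in place of 1H-indol-3-yl on a saturated chain carbon bound to an amine nitrogen in a ring changes inhibition at all.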